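A Second Methoxy Group on a Shared Core

The compounds below may be only part of what the source reports. "The series", "measured", "known", "first", "only" and "open" are said of these compounds alone.

Measured compounds:
compound 1, `COc1ccc(-c2cc(/C=C/C(=O)c3ccc(N)cc3)[nH]n2)cc1`: 103%
compound 2, `COc1cc(-c2cc(/C=C/C(=O)c3ccc(Cl)c(Cl)c3)[nH]n2)cc(OC)c1OC`: 104%
compound 3, `COc1ccc(C(=O)/C=C/c2cc(-c3cc(OC)c(OC)c(OC)c3)n[nH]2)cc1`: 99%

All three were tested in a functional assay on SK-OV-3 cells (Homo sapiens) for cytotoxicity, read by sulforhodamine B assay, with a stated time of 48 h, tested at 0.1 uM; on this read-out lower numbers stand for a stronger effect and higher numbers for a weaker effect at the one concentration tested. Compound 1 gives 103%, and this number lies alongside those of compound 2 and compound 3, all within the usual scatter of one another, so none of the three can be told apart on this read-out.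

The unmeasured compound 4, `COc1ccc(-c2cc(/C=C/C(=O)c3ccc(N)cc3)[nH]n2)cc1OC`, differs from compound 1 in one place: methoxy in place of hydrogen on an aromatic carbon. The new group sits on an aromatic carbon of a six-membered aromatic ring of carbon only, ortho to a methoxy group and meta to a large group.

Going by the values given here, only one measured step is available, a number 5 percentage points lower from compound 2 to compound 3 (within the scatter), and it concerns a different part of the shared core, the group on the carbonyl carbon, not the ring where compound 4 gains its methoxy group. Among the compounds with values here, no measured pair shows what adding a methoxy group does here. Within the data shown here, since every number so far sits near the same level, compound 4 is expected to show a step of a number 2 percentage points lower from compound 1 to compound 4 (within the scatter), none beyond the scatter. The estimate for compound 4 is 101%, within a range from 90% to 112%.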

Compound 4, a percentage reported as activity, at one concentration (the size of the read-out at that concentration, not a potency): 102%
Compound 4: the middle estimate sits 1 percentage points below what was measured, within the range that was stated.
By their numbers in this assay, from the lowest: compounds 3, 4, 1 and 2 (each within the scatter of the next).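

In this assay, adding the methoxy group gives a number 1 percentage points lower from compound 1 to compound 4 (within the scatter), so at the one concentration tested, this change on an aromatic carbon, ortho to a methoxy group and meta to a large group, produces no difference that can be told apart from the scatter. Going by these compounds alone, the earlier step concerned only the group on the carbonyl carbon, so this pair is the first direct test of a change at this position, and it shows that this methoxy group can be added without a measurable shift on this read-out. Nothing measured here offers an explanation for this result.

The compounds shown leave open whether a different group at the same position, such as an amine, a carboxylic acid or a longer chain like butoxy, would move the number beyond the scatter. They also leave open whether the same methoxy group would make a measurable difference at another concentration, or on a core carrying a different group on the carbonyl carbon.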